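Iodo Substitution on a Pyridinone Core: Expected Cytotoxicity

The source may hold more compounds than are shown below. What is called first, only, known or untested is meant among the compounds shown, and "the series" means these compounds.

Compound 1 `Cc1cc(C)c(Oc2cc(Nc3ccc(C#N)cc3)[nH]c(=O)c2)c(C)c1` was tested in an ADME assay on MT4 cells (Homo sapiens) for cytotoxicity, read by MTT assay, with a stated time of 5 days (on this read-out higher numbers stand for lower toxicity in this test and lower numbers for higher toxicity in this test), and gives 32000 nM. Within the data shown here, its closest neighbour, compound 2 `Cc1cccc(C)c1Oc1cc(Nc2ccc(C#N)cc2)[nH]c(=O)c1`, gives 36000 nM in this assay, and the two values lie within the scatter of each other: the step of a 1.1-fold higher number from compound 1 to compound 2 (0.05 log units; within the scatter) is the only measured step in this set and does not separate the pair.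

Compound 3 `Cc1cc(C)c(Oc2cc(Nc3ccc(C#N)cc3)[nH]c(=O)c2I)c(C)c1` differs from compound 1 by iodo in place of hydrogen on an aromatic carbon, on the aromatic carbon para to the (4-cyanophenyl)amino group. Among the measured compounds shown here, no measured step involves this change; the one step available concerns a methyl group on the other ring, and it was within the scatter. The data therefore give no basis for expecting a step beyond the scatter in this assay, and compound 3 is expected to give 25000 nM, with a range of 8000 nM to 65000 nM. The step this implies, a 1.3-fold lower number from compound 1 to compound 3 (0.11 log units; within the scatter), is an estimate, not a measurement.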

Compound 3, half-maximal cytotoxic concentration: 34000 nM
The estimate for compound 3 lay 1.4-fold (0.13 log units) below the measured number; low and high end bracket the measured number.
By their numbers in this assay, from the lowest: compounds 1, 3 and 2 (each within the scatter of the next).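

In this assay, iodo in place of hydrogen on the aromatic carbon para to the (4-cyanophenyl)amino group, two atoms from the ring nitrogen, gives a 1.1-fold higher number from compound 1 to compound 3 (0.03 log units; within the scatter), so this single-atom change does not separate compound 3 from compound 1. Among these compounds, the earlier pair spoke only to a methyl group elsewhere in the molecule, whereas this result is the first reading at this carbon, and it shows that iodo here leaves the number within the scatter of the parent. Nothing given here bears on why the number behaves this way.

From the compounds shown here alone, it remains open whether a group of another kind at this carbon, such as an amine or a carboxylic acid, would also stay within the scatter of compound 1. The compounds shown also leave open whether iodo at this carbon would read the same on the core of compound 2.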